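Chloro to Bromo on a Quinolinone Benzimidazole

A few compounds are considered here, and "the series" means these few. Any claim that something is new, unique, unknown or untested is made for them only; others in the source may bear on it.

Measured compounds:
compound 1, `Cc1ccc2[nH]c(=O)c(-c3nc4cc(Cl)ccc4[nH]3)cc2c1`: 39000 nM
compound 2, `O=c1[nH]c2ccccc2cc1-c1nc2cc([N+](=O)[O-])ccc2[nH]1`: > 100000 nM
compound 3, `COc1ccc2[nH]c(=O)c(-c3nc4cc(C)c(C)cc4[nH]3)cc2c1`: > 100000 nM

The series rests on a shared core carrying three compounds with readings in a functional assay on BEL-7404 cells for cytotoxicity against BEL-7404 tumor cell line (Homo sapiens), read by MTT assay, with a stated time of 48 h; on this read-out lower numbers stand for stronger inhibition and higher numbers for weaker inhibition. In this assay, for the measured compounds named here, compound 1 gives 39000 nM, and it is the only compound for which a number rather than a limit is available. For compound 2 the result in this assay is > 100000 nM, which is a limit of the assay and not a number. For compound 3 the result in this assay is likewise a limit, > 100000 nM. The remaining two readings therefore sit at the limit of > 100000 nM in this assay, at which 2 of the 3 values shown sit, and compound 1 alone anchors the series with a measured value.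

Compound 4, `Cc1ccc2[nH]c(=O)c(-c3nc4cc(Br)ccc4[nH]3)cc2c1`, has not yet been measured. It differs from compound 1 by bromo in place of chloro on an aromatic carbon. An exchange of one halogen for the other of about the same size is expected to move the read-out little, so the step from compound 1 to compound 4 is expected to fall within the usual scatter, a 1.1-fold lower number from compound 1 to compound 4 (0.05 log units; within the scatter). Compound 4 is accordingly estimated at 35000 nM, with a likely range from 12000 nM to 100000 nM.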

Compound 4, half-maximal inhibitory concentration: > 100000 nM
Compound 4: only a limit was reported (the forecaster's own chance of this, stated with the estimate: 20%); middle value at least 2.8-fold (0.45 log units) away from the limit.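

In this assay compound 4 gives > 100000 nM, which is a limit of the assay and not a number. For the compounds shown here, exchanging chloro for bromo on this aromatic carbon produces an at least 2.5-fold higher number from compound 1 to compound 4 (0.40 log units; beyond the scatter), showing that this position is sensitive even to a change from one halogen to the other, something the earlier compounds, which differ from compound 1 in more than one place, could not show. Compound 1 is now the only one of the series with a measured reading, and the others share a ceiling: the limit of > 100000 nM in this assay, at which 3 of the 4 values shown sit.

On these data alone, how far compound 4 lies beyond its limit remains open, so the full size of the step cannot be read. Also open, as far as these compounds go, is whether fluoro, an amine or a carboxylic acid on this aromatic carbon would give a measurable reading, as chloro does in compound 1.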